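The source may hold more compounds than are shown below. What is called first, only, known or untested is meant among the compounds shown, and "the series" means these compounds.

Of the compounds shown here, three have been measured in an assay for inhibition of Amine oxidase [flavin-containing] B (Rattus norvegicus); a higher number here means a weaker inhibitor, a lower number a stronger inhibitor. Compound 1 `Cc1cccc(COc2ccc(-c3nn(CCC#N)c(=O)o3)cc2)c1` gives 8 nM. Compound 2 `CC(C#N)Cn1nc(-c2ccc(OCc3ccccc3)cc2)oc1=O` gives 2400 nM. Compound 3 `N#CCCN1N=C(c2ccc(OCc3ccccc3)cc2)OCC1=O` gives 18 nM, the second highest of the three numbers. Compound 1 is its nearest neighbour, with a lower number, and compound 2 its furthest, with a much higher number; both gaps lie beyond the usual scatter of repeated measurements. Among the measured compounds shown here, no pair of measured compounds differs in only a single place, so nothing yet shows how one change at a time moves the numbers.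

Compound 4 `N#CCCN1N=C(c2ccc(OCc3ccc([N+](=O)[O-])cc3)cc2)OCC1=O` has not been measured. It differs from compound 3 in one place: nitro in place of hydrogen on an aromatic carbon. Cut one bond further out, the change reads phenyl to 4-nitrophenyl. For the measured compounds named here, with no measured single-place step to lean on, the expectation rests on the change alone, and only a modest step is expected, if any. Compound 4 is estimated at 30 nM, within a range from 8 nM to 120 nM. The step expected in this assay is a 1.7-fold higher number from compound 3 to compound 4 (0.22 log units; within the scatter), leaning towards a somewhat higher number, though the range also covers no change beyond the scatter.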

Compound 4, half-maximal inhibitory concentration: 300 nM
Compound 4: the middle estimate sits 10-fold (1.00 log units) below what was measured; the measured number lies above the stated range.
By their numbers in this assay, from the lowest: compound 1; then compound 3; then compound 4; then compound 2.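

In this assay, putting nitro in place of hydrogen gives a 17-fold higher number from compound 3 to compound 4 (1.22 log units; beyond the scatter), a large step and the first in this series that comes from a change in one place only. It shows that this aromatic carbon, para to a large group, is not a place where any added group leaves the number unchanged: here, three added heavy atoms make the inhibitor clearly weaker, although compound 4 still gives a measurable value. The result records the size and direction of this change but not its cause, and no separate measurement bears on why the number rises.

This is a single replacement at a single place, so it cannot yet show whether the rise belongs to nitro in particular or would follow from other groups on the same carbon, such as a fluorine atom, a methoxy group or an amine. It also leaves open whether nitro on a different carbon of that ring would produce a step of similar size.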